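One ring exchange, one compound still to measure

The source may hold more compounds than are shown below. What is called first, only, known or untested is meant among the compounds shown, and "the series" means these compounds.

The three measured compounds were all run in an ADME assay on BV-2 cells (Mus musculus) for cytotoxicity, with a stated time of 24 h, tested at 10 uM; a lower number here means a stronger effect, a higher number a weaker effect of the compound at the concentration tested.

Compound 1 `COc1ccccc1S(=O)(=O)/C=C/c1ccncc1`: 96.8%
Compound 2 `COc1cccc(S(=O)(=O)/C=C/c2ccncc2)c1`: 84.3%
Compound 3 `COc1ccccc1S(=O)(=O)/C=C/c1cncnc1`: 100%

Compound 1 and compound 3 share a core and differ by pyrimidin-5-yl in place of pyridin-4-yl on a double-bonded chain carbon bound to a double-bonded chain carbon. This step gives a number 3.2 percentage points higher from compound 1 to compound 3 (within the scatter), so the two read-outs are indistinguishable within the usual scatter.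

Compound 2 has the same atoms as compound 1 joined differently; the difference between the two cores is not broken down here. Compound 2 sits lowest of the three, separated from compound 1 and from compound 3 by more than the scatter.

Compound 4 `COc1cccc(S(=O)(=O)/C=C/c2cncnc2)c1` has not yet been measured. It stands to compound 2 as compound 3 stands to compound 1, differing by pyrimidin-5-yl in place of pyridin-4-yl on a double-bonded chain carbon bound to a double-bonded chain carbon. The place of the change is the same in both pairs, so this is the same change made on the other core. It occurs twice among the four compounds, once measured and once pending.

For the measured compounds named here, the expectation for compound 4 rests on the one measured instance: because a number 3.2 percentage points higher from compound 1 to compound 3 (within the scatter) was within the scatter, the step from compound 2 to compound 4 is estimated as a number 2.7 percentage points higher from compound 2 to compound 4 (within the scatter), a small shift of the same kind. Compound 4 is accordingly expected to give about 87% in this assay, with a likely range from 74% to 100%. Whether the lower level of compound 2 relative to compound 1 carries over to compound 4 relative to compound 3 is the open point this measurement will settle.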

Compound 4, a percentage reported as activity, at one concentration (the size of the read-out at that concentration, not a potency): 100%
Compound 4: the middle estimate sits 13 percentage points below what was measured; measured number inside the range.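

In this assay, pyrimidin-5-yl in place of pyridin-4-yl on a double-bonded chain carbon bound to a double-bonded chain carbon gives a number 15.7 percentage points higher from compound 2 to compound 4 (beyond the scatter). Set beside the same change on the other core, this step does not separate from the earlier one: the same change on two cores in this assay, a number 3.2 percentage points higher (within the scatter) from compound 1 to compound 3 and a number 15.7 percentage points higher (beyond the scatter) from compound 2 to compound 4, 12.5 percentage points apart, within the scatter of two such steps. For the compounds shown here, the series therefore gives no ground for saying that the change behaves differently on the two cores, and the step measured on one core is a usable first guide to the step on the other; it does not show that the change behaves identically, since each core contributes a single pair and only the step on the core of compound 2 lies beyond the scatter.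

The compounds shown leave open how a phenyl group, or a ring carrying an amine or a carboxylic acid, would read at the same place on either core. They also leave open whether the two steps would stay together at concentrations other than the single one tested, and whether they would hold with a group other than methoxy on the shared core.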